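This account rests on a few compounds, and the source may have more. Where it says the series, first, only, none or still open, it means among the compounds named here.

In an in vivo ADME assay on the whole organism for pharmacokinetics, with Rattus norvegicus as the target (a lower number here means slower removal, a higher number faster removal of the compound), compound 1 `O=C(NC1CCCCC1)N1CCN(c2nc(-c3ccc4ccccc4n3)no2)CC1` gives 54 mL/min/kg and sits at the upper end of the three numbers available. Compound 2 `O=C(NC1CCS(=O)(=O)CC1)N1CCC(c2nc(-c3ccc4ccccc4n3)no2)CC1` gives 40 mL/min/kg and stays within the scatter of compound 1. Compound 3 `Cn1c(-c2noc(C3CCN(C(=O)NC4CCCCC4)CC3)n2)nc2ccccc21` gives 26 mL/min/kg and lies lower than compound 1 by more than the scatter. Among the compounds with values here, compound 4 `Cn1c(-c2noc(N3CCN(C(=O)NC4CCCCC4)CC3)n2)nc2ccccc21` has no measurement yet. Its change from compound 1 is 1-methyl-1H-benzimidazol-2-yl in place of quinolin-2-yl on an aromatic carbon with 1-methyl-1H-benzimidazol-2-yl in place of quinolin-2-yl on an aromatic carbon. Within the data shown here, compound 3 also carries 1-methyl-1H-benzimidazol-2-yl and gives 26 mL/min/kg as the only measured compound with that group, so the support is indirect. A modest fall, probably inside the scatter, is expected as the estimated 1.5-fold lower number from compound 1 to compound 4 (0.19 log units; within the scatter) in this assay for this change. For compound 4 the estimated clearance is 35 mL/min/kg within a range of 20 mL/min/kg to 60 mL/min/kg as a working figure.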

Compound 4, clearance in the Rattus norvegicus assay: 26 mL/min/kg
Compound 4: middle estimate off by 1.3-fold (0.13 log units), on the high side; the measured number falls inside the stated range.
By their numbers in the Rattus norvegicus assay, from the lowest: compounds 3, 4, 2 and 1 (each within the scatter of the next, the first and the last beyond it).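

Within the data shown here, on an aromatic carbon of the shared core, this is the first direct reading of 1-methyl-1H-benzimidazol-2-yl in place of quinolin-2-yl: in the Rattus norvegicus assay compound 1 gives 54 mL/min/kg and compound 4 gives 26 mL/min/kg and the Rattus norvegicus assay shows a 2.1-fold lower number from compound 1 to compound 4 (0.32 log units; beyond the scatter) as a step beyond the scatter. In a physicochemical assay for lipophilicity (on this read-out higher numbers stand for higher lipophilicity and lower numbers for lower lipophilicity), compound 1 gives 2.76 and compound 4 gives 2.57 and the same change gives a number 0.19 log units lower from compound 1 to compound 4 (within the scatter) and stays within the scatter. Nothing available accounts for the clearance step. Still open, as far as these compounds go, is whether the methyl on the ring nitrogen matters, as the unsubstituted 1H-benzimidazol-2-yl would show. From the compounds shown here alone, a smaller group such as pyridin-2-yl at this position is equally open.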